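From Amine to Alcohol on the Shared Core

A few compounds are considered here, and "the series" means these few. Any claim that something is new, unique, unknown or untested is made for them only; others in the source may bear on it.

Compound 1 `COc1ccc(CNCc2c(OC)cc(Oc3cccc(Nc4ccccc4)c3)cc2OC)cc1`: 2620 nM
Compound 2 `CNCc1c(OC)cc(Oc2cccc(Nc3ccccc3)c2)cc1OC`: > 20000 nM
Compound 3 `COc1cc(Oc2cccc(Nc3ccccc3)c2)cc(OC)c1CN(C)C`: 12900 nM

In a functional assay on HCT-116 cells (Homo sapiens) for inhibition, read by MTT assay, with a stated time of 72 h (a lower number here means a stronger inhibitor, a higher number a weaker inhibitor), compound 1 gives 2620 nM. Compound 2 reaches only the limit of the assay, > 20000 nM. Compound 3 gives 12900 nM, the highest of the two numbers shown, through a 4.9-fold higher number from compound 1 to compound 3 (0.69 log units; beyond the scatter). The step of an at least 1.5-fold lower number from compound 2 to compound 3 (0.19 log units; that floor lies within the scatter) begins at a limit, and its floor sits within the scatter.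

Compound 4 `COc1cc(Oc2cccc(Nc3ccccc3)c2)cc(OC)c1CCO` differs from compound 3 by hydroxymethyl in place of dimethylamino on a saturated chain carbon bound to an aromatic carbon. Both measured steps, a 4.9-fold higher number from compound 1 to compound 3 (0.69 log units; beyond the scatter) and an at least 1.5-fold lower number from compound 2 to compound 3 (0.19 log units; that floor lies within the scatter), keep an amine nitrogen at that carbon; neither removes it. Because every change at this carbon so far has given a weaker compound, by a 4.9-fold higher number from compound 1 to compound 3 (0.69 log units; beyond the scatter), compound 4 is expected to move further the same way, a 1.7-fold higher number from compound 3 to compound 4 (0.23 log units; within the scatter), with a real chance of only a limit. Compound 4 is estimated at 22000 nM, between 7000 nM and 70000 nM.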

Compound 4, half-maximal inhibitory concentration: > 20000 nM
Compound 4: no number, only a limit; the forecaster's own chance of this, stated with the estimate: 55%; the middle value is on the limit's open side.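

In this assay compound 4 gives only a limit, > 20000 nM. For the compounds shown here, with hydroxymethyl, this carbon carries no amine nitrogen for the first time, yet an at least 1.5-fold higher number from compound 3 to compound 4 (0.19 log units; that floor lies within the scatter) does not separate the alcohol from dimethylamino, while an at least 7.6-fold higher number from compound 1 to compound 4 (0.88 log units; beyond the scatter) places it clearly behind the (4-methoxybenzyl)amino group. The step between compound 2 and compound 4 cannot be read, and the limit bounds what these weak compounds can show: the limit of > 20000 nM in this assay, at which 2 of the 4 values shown sit.

As far as these compounds go, whether the amine nitrogen or the 4-methoxybenzyl group matters more stays open. A 4-methoxybenzyl ether at this carbon could separate the two, and a carboxylic acid there remains untested among the compounds shown.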